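Taking the Methyl Off an Oxygen: Compound 3 to 4

The source may report more compounds than this note shows. Statements on the series, on what has been measured and on what is new or still open speak of the compounds shown alone.

Compound 1 `COc1cc(C)cc(-c2c(-c3ccnc(-c4ccc(C(C)=O)cc4)c3)cnn2CC#N)c1` gives 95% in a functional assay on A549 cells (Homo sapiens) for cytotoxicity, read by sulforhodamine B assay, with a stated time of 48 h, tested at 0.001 uM; on this read-out higher numbers stand for a weaker effect at the one concentration tested and lower numbers for a stronger effect.
Compound 2 `Cc1cc(O)cc(-c2nn(CC#N)cc2-c2ccnc(-c3ccc(Oc4ccccc4)cc3)c2)c1` gives 96%.
Compound 3 `COc1cc(C)cc(-c2nn(CC#N)cc2-c2ccnc(-c3ccc(N(C)C)cc3)c2)c1` gives 97%.

All three numbers lie within the usual scatter of one another, so compound 3 stands level with compound 2 and compound 1: the gap from its value to either of theirs is no wider than repeat measurements would give. Compound 4 `Cc1cc(O)cc(-c2nn(CC#N)cc2-c2ccnc(-c3ccc(N(C)C)cc3)c2)c1` is reached from compound 3 by one change: hydrogen in place of methyl on an oxygen on an aromatic ring. Compound 2 already carries the hydroxy group that compound 4 gains, and its value sits beside those of compound 1 and compound 3, so nothing seen so far ties this change to a shift in the read-out. The step from compound 3 to compound 4 in this assay is expected to be a number 1 percentage points lower from compound 3 to compound 4 (within the scatter), none beyond the scatter. Compound 4 is estimated at 96%, with a range from 88% to 100%.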

Compound 4, a percentage reported as activity, at one concentration (the size of the read-out at that concentration, not a potency): 104%
Compound 4: middle estimate off by 8 percentage points, on the low side; the measured number lies above the stated range.
By their numbers in this assay, from the lowest: compounds 1, 2, 3 and 4 (each within the scatter of the next).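

Hydroxy in place of methoxy gives a number 7 percentage points higher from compound 3 to compound 4 (within the scatter), so this position now has a direct one-place comparison, and at this single low concentration the swap moves the read-out no further than repeat measurements would. Dimethylamino in place of phenoxy on an aromatic carbon gives a number 8 percentage points higher from compound 2 to compound 4 (within the scatter), so that second site also shows no shift beyond the scatter. Nothing measured here offers an explanation for these numbers.

The compounds shown leave open whether a larger group on that oxygen, such as ethoxy, would separate from these values. They also leave open whether an amine in place of the hydroxy would do so.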